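Swapping isobutyl for isopropoxy on a sulfamoyl carbamate

The compounds below may be only part of what the source reports. "The series", "measured", "known", "first", "only" and "open" are said of these compounds alone.

Measured so far:
Compound 1 `COCCOC(=O)NS(=O)(=O)c1sc(CC(C)C)cc1-c1ccc(Cn2ccnc2)cc1` gives, in an assay on membranes from liver for displacement of a labelled ligand from Type-2 angiotensin II receptor (Rattus norvegicus) (a lower number here means a stronger inhibitor, a higher number a weaker inhibitor), a value of > 10000 nM, which is a limit of the measurement and not a number.
Compound 2 `CCCCOC(=O)NS(=O)(=O)c1ccc(CC(C)C)cc1-c1ccc(Cn2ccnc2)cc1` gives in this assay a value of > 10000 nM, again a limit rather than a number.
Compound 3 `CCCCc1ccc(S(=O)(=O)NC(=O)OCC)c(-c2ccc(Cn3ccnc3)cc2)c1` gives in this assay a value of > 10000 nM, also a limit.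

Among the measured compounds shown here, compound 2 therefore stands at the limit of > 10000 nM in this assay, at which 3 of the 3 values shown sit; no single compound among the three can be called stronger or weaker than another, since every value is a limit. No pair of these compounds differs in just one place, so no measured step is available to lean on.

The new compound, compound 4 `CCCCOC(=O)NS(=O)(=O)c1ccc(OC(C)C)cc1-c1ccc(Cn2ccnc2)cc1`, differs from compound 2 in one place: isopropoxy in place of isobutyl on an aromatic carbon. With all measured values at a limit, there is no basis for expecting a step in either direction beyond the scatter. Compound 4 is expected to give 15000 nM, within a range from 5000 nM to 50000 nM. This estimate corresponds to an expected step that the limit leaves unreadable from compound 2 to compound 4, most likely ending once more at a limit.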

Compound 4, inhibition constant: > 10000 nM
Compound 4 was reported as a limit; the forecaster's own chance of this, stated with the estimate: 80%; the middle value is on the limit's open side.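

Compound 2 and compound 4 are both reported only as limits in this assay, so no step can be read between them: the limit of > 10000 nM in this assay, at which 4 of the 4 values shown sit.

The compounds shown leave open whether isopropoxy in place of isobutyl changes inhibition at all, and how any of the four ranks against the others.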